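Pentyl in Place of Phenylethyl on an Acylguanidine Core

A few compounds are considered here, and "the series" means these few. Any claim that something is new, unique, unknown or untested is made for them only; others in the source may bear on it.

Compound 1 `Cc1nc(N)sc1CCCN/C(N)=N/C(=O)N[C@H](C)c1ccccc1` is a guanidine bearing an aminothiazole chain and a 1-phenylethyl group on the amide-type nitrogen. In a functional assay on HEK293T cells for agonist activity at histamine H2 receptor (Homo sapiens), read by beta-arrestin recruitment (a lower number here means a smaller maximal response, a higher number a larger maximal response), compound 1 gives 0.34, the higher of the two numbers reported; its nearest neighbour, compound 3 `Cc1nc(N)sc1CCCN/C(N)=N/C(=S)N[C@H](C)c1ccccc1`, gives 0.11 in this assay, a value that lies beyond the usual scatter below it. Compound 2 `CCCCCCNC(=O)/N=C(\N)Nc1cccc(-c2csc(N)n2)c1` belongs to the same series, but in this assay compound 2 gives "not determined" (no result reported), that is, no result was reported for it.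

Compound 4 `CCCCCNC(=O)/N=C(\N)NCCCc1sc(N)nc1C` differs from compound 1 in one place: pentyl in place of 1-phenylethyl on an amide-type nitrogen. Among the measured compounds shown here, no pair of measured compounds shows this kind of change, so the size of the step can only be guessed. Without a measured precedent, the step from compound 1 to compound 4 in this assay is expected to be a number 0.010 higher from compound 1 to compound 4 (within the scatter), which is to say no change beyond the scatter in either direction. Compound 4 is therefore estimated to give 0.35 in this assay, within a range from 0.1 to 0.6.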

Compound 4, intrinsic activity: the largest response reached, as a fraction of the reference agonist's: 0.15
Compound 4: middle estimate off by 0.20, on the high side; the measured number falls inside the stated range.
By their numbers in this assay, from the lowest: compounds 3 and 4 (each within the scatter of the next); then compound 1.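

In this assay, pentyl in place of 1-phenylethyl on the amide-type nitrogen gives a number 0.19 lower from compound 1 to compound 4 (beyond the scatter), the first measured sign that the maximal response depends on the group held at this position. The change removes the six-membered aromatic ring and the defined stereocentre together and alters the carbon count, so this single step cannot separate their contributions. No measurement shown here explains the lower response.

Still open, from the compounds shown here alone, is how benzyl, which keeps the aromatic ring without a stereocentre, or cyclohexyl, which keeps a ring without aromaticity, would compare on this nitrogen. Also open, going by these compounds, is whether pentyl would shift the response in the same way on the core of compound 3, which gives 0.11 in this assay.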